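This account rests on a few compounds, and the source may have more. Where it says the series, first, only, none or still open, it means among the compounds named here.

Compound 1 `CC(C)n1c(=O)n(C(=O)NCCN2CCN(C)CC2)c2ccccc21` is the reference point of the series. In a functional assay for antagonist activity at 5-hydroxytryptamine receptor 4 (Cavia porcellus) (on this read-out higher numbers stand for higher potency (the scale is a negative logarithm) and lower numbers for lower potency), compound 1 gives only the assay limit < 6, not a number. Compound 2 `CCN1CCN(CCNC(=O)n2c(=O)n(C(C)C)c3ccccc32)CC1` reaches 6.62 in this assay. The step of a number at least 0.62 log units higher from compound 1 to compound 2 (beyond the scatter) is the only one read in full. Compound 3 `CN1CCN(CCNC(=O)n2c(=O)n(C)c3ccccc32)CC1` likewise stops at the limit < 6 in this assay. The step that the two limits leave unreadable from compound 1 to compound 3 stays unreadable, (the limit of < 6 in this assay, at which 2 of the 3 values shown sit). Compound 4 `COc1ccc2c(c1)n(C(=O)NCCN1CCN(C)CC1)c(=O)n2C(C)C` differs from compound 1 by methoxy in place of hydrogen on an aromatic carbon. Going by the values given here, neither measured step touches the carbon ring of the shared core: one alters the amine side, the other the aromatic nitrogen, so no direct precedent exists. Compound 4 is expected to stay close to the limit, a step that the limit leaves unreadable from compound 1 to compound 4. The estimate for compound 4 in this assay is 5.8, range 5 to 6.5.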

Compound 4, negative logarithm of the antagonist equilibrium constant: < 6
Compound 4 gave a limit, no number; the forecaster's own chance of this, stated with the estimate: 60%; the middle value is on the limit's open side.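

Going by these compounds alone, compound 1 and compound 4 both stop at an assay limit, so no step between them can be read: the limit of < 6 in this assay, at which 3 of the 4 values shown sit. In this assay, from the compounds shown here alone, the effect of methoxy in place of hydrogen on an aromatic carbon stays open.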